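The source may hold more compounds than are shown below. What is called first, only, known or untested is meant among the compounds shown, and "the series" means these compounds.

Measured in an assay on Sf9 cells for inhibition of serine/threonine-protein kinase 4 (Homo sapiens), read by luminescence and ADP-Glo, with a stated time of 1 h, in the presence of a further agent that is not named here; a lower number here means a stronger inhibitor, a higher number a weaker inhibitor:
compound 1 `CN1CC(=O)N(C)c2cnc(Nc3ccc(S(N)(=O)=O)cc3)nc21` gives 495 nM
compound 2 `CN1C(=O)C(CC2CC2)N(C)c2nc(Nc3ccc(S(N)(=O)=O)cc3)ncc21` gives 211 nM
compound 3 `COc1cccc(C2C(=O)N(C)c3cnc(Nc4ccc(S(N)(=O)=O)cc4)nc3N2C)c1` gives 954 nM

Compound 3 has the highest number of the three; the two gaps are a 1.9-fold higher number from compound 1 to compound 3 (0.28 log units; within the scatter) and a 4.5-fold higher number from compound 2 to compound 3 (0.66 log units; beyond the scatter).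

Compound 4 `CN1C(=O)C(c2cccs2)N(C)c2nc(Nc3ccc(S(N)(=O)=O)cc3)ncc21` differs from compound 3 in one place: thiophen-2-yl in place of 3-methoxyphenyl on a saturated ring carbon. Among the compounds with values here, the steps that bear on this change are the two at the same saturated ring carbon: hydrogen to 3-methoxyphenyl, a 1.9-fold higher number from compound 1 to compound 3 (0.28 log units; within the scatter), and cyclopropylmethyl to 3-methoxyphenyl, a 4.5-fold higher number from compound 2 to compound 3 (0.66 log units; beyond the scatter). Within the data shown here, no measured step swaps one aromatic group for another at this carbon, so no direction beyond the scatter is expected; the number for compound 4 is expected to sit between those of compound 1 and compound 3, a step of a 1.5-fold lower number from compound 3 to compound 4 (0.17 log units; within the scatter). Compound 4 is therefore estimated at 650 nM, range 250 nM to 1700 nM.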

Compound 4, half-maximal inhibitory concentration: 88 nM
Compound 4: the middle estimate sits 7.4-fold (0.87 log units) above what was measured, and the stated range ends above it.
By their numbers in this assay, from the lowest: compound 4; then compound 2; then compounds 1 and 3 (each within the scatter of the next).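

At this saturated ring carbon, the identity of the aromatic group matters: replacing 3-methoxyphenyl with thiophen-2-yl gives the largest step in the series (an 11-fold lower number from compound 3 to compound 4 (1.04 log units; beyond the scatter)). Thiophen-2-yl also gives a lower number than hydrogen (a 5.6-fold lower number from compound 1 to compound 4 (0.75 log units; beyond the scatter)) and cyclopropylmethyl (a 2.4-fold lower number from compound 2 to compound 4 (0.38 log units; beyond the scatter)), whereas the step from hydrogen to 3-methoxyphenyl stays within the scatter. No measurement available here accounts for the difference between the two aromatic groups. Going by these compounds, it remains open whether the gain follows the five-membered sulfur-containing ring or the absence of methoxy; unsubstituted phenyl and furan-2-yl would separate these. On these data alone, the effect of an amine at this carbon also remains open.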